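A few compounds are considered here, and "the series" means these few. Any claim that something is new, unique, unknown or untested is made for them only; others in the source may bear on it.

Of the compounds shown here, three that share one core have been tested in an assay on MDA-MB-231 cells for binding affinity to C-X-C chemokine receptor type 4 (Homo sapiens), read by microscopy, with stated times of 10 min and 30 min; on this read-out higher numbers stand for an effect only at larger amounts of compound and lower numbers for an effect already at smaller amounts. Compound 1 `Cc1cccc(S(=O)(=O)NCc2ccc(CNC(=O)c3ccc(CNc4ncccn4)cc3)cc2)c1` gives 100 nM, compound 2 `O=C(NCc1ccc(CNS(=O)(=O)c2ccc(Cl)cc2)cc1)c1ccc(CNc2ncccn2)cc1` gives 100 nM, and compound 3 `O=C(NCc1ccc(CNS(=O)(=O)c2cccc(C(F)(F)F)c2)cc1)c1ccc(CNc2ncccn2)cc1` gives 1000 nM, the highest of the three numbers. Compound 4 `O=C(NCc1ccc(CNS(=O)(=O)c2ccccc2Cl)cc1)c1ccc(CNc2ncccn2)cc1` is the one still to be measured; it differs from compound 3 by 2-chlorophenyl in place of 3-(trifluoromethyl)phenyl on a sulfonyl sulfur. For the measured compounds named here, two measured steps bear on this: a 10-fold higher number from compound 2 to compound 3 (1.00 log units; beyond the scatter), and a 10-fold higher number from compound 1 to compound 3 (1.00 log units; beyond the scatter), while no change at the digits printed from compound 1 to compound 2 (within the scatter). Going by the values given here, compound 4 gives up the trifluoromethyl group and brings back a chlorophenyl, so the number is expected to fall back toward those of compound 1 and compound 2, though the move from 4-chlorophenyl to 2-chlorophenyl has no measured counterpart. The step is estimated as a 6.7-fold lower number from compound 3 to compound 4 (0.82 log units; beyond the scatter). Compound 4 is therefore expected at 150 nM, within 50 nM to 600 nM.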

Compound 4, effective concentration (reported as EC, without a stated level of effect): 1000 nM
The estimate for compound 4 lay 6.7-fold (0.82 log units) below the measured number, and the stated range ends below it.
By their numbers in this assay, from the lowest: compounds 1 and 2 (each within the scatter of the next); then compounds 3 and 4 (each within the scatter of the next).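

In this assay, 2-chlorophenyl in place of 4-chlorophenyl on the sulfonyl sulfur gives a 10-fold higher number from compound 2 to compound 4 (1.00 log units; beyond the scatter), so a chlorophenyl group alone does not bring back the lower number; the comparison with 3-methylphenyl agrees, with a 10-fold higher number from compound 1 to compound 4 (1.00 log units; beyond the scatter). Against 3-(trifluoromethyl)phenyl, the same group shows no change at the digits printed from compound 3 to compound 4 (within the scatter), so the higher number is not tied to trifluoromethyl. No measurement at hand explains these results. Going by these compounds, what an amine or a carboxylic acid on this ring would give stays open, as does the number for a plain phenyl ring.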